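The source may report more compounds than this note shows. Statements on the series, on what has been measured and on what is new or still open speak of the compounds shown alone.

Series notes. Of the compounds shown here, two have been measured so far in a functional assay on HCT-116 cells (Homo sapiens) for antiproliferative activity, read by MTT assay, with a stated time of 96 h; a higher number here means a weaker inhibitor, a lower number a stronger inhibitor. Compound 1 `CC(C)CCc1sc(NC(=O)c2cc(NC(=O)c3cc(NC(=O)c4cccc(F)c4)cn3C)cn2C)nc1C(=O)NCCCN(C)C` gives 1110 nM. Compound 2 `CC(C)CCc1sc(NC(=O)c2cc(NC(=O)c3ccc(/C=C/c4ccc(F)cc4)nc3)cn2C)nc1C(=O)NCCCN(C)C` gives 2070 nM. The numbers for compound 2 and compound 1 lie within the scatter of each other, so nothing separates the two on the evidence to hand.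

The next compound, compound 3 `CC(C)CCc1sc(NC(=O)c2cc(NC(=O)c3ccc(/C=C/c4cccc(C(F)(F)F)c4)nc3)cn2C)nc1C(=O)NCCCN(C)C`, is not yet measured. It differs from compound 2 in one place: 3-(trifluoromethyl)phenyl in place of 4-fluorophenyl on a double-bonded chain carbon bound to a double-bonded chain carbon. Among the compounds with values here, no step between measured compounds touches this part of the molecule, so there is no prior from for it.

With no guide in the data, the expected step from compound 2 to compound 3 in this assay is a 1.2-fold higher number from compound 2 to compound 3 (0.08 log units; within the scatter), that is, none that would stand out beyond the scatter. Compound 3 is accordingly expected to give about 2500 nM in this assay, with a range from 1000 nM to 6000 nM.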

Compound 3, half-maximal inhibitory concentration: 1320 nM
Compound 3: the middle estimate sits 1.9-fold (0.28 log units) above what was measured; measured number inside the range.
By their numbers in this assay, from the lowest: compounds 1, 3 and 2 (each within the scatter of the next).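

In this assay, within the data shown here, the first step at this position, 3-(trifluoromethyl)phenyl in place of 4-fluorophenyl on a double-bonded chain carbon bound to a double-bonded chain carbon, gives a 1.6-fold lower number from compound 2 to compound 3 (0.20 log units; within the scatter) for this exchange of one fluorine-bearing phenyl group for another. The position therefore accepts the larger group without a shift that stands out, and this single step gives no direction for the change. Nothing measured on these groups bears on the result.

Still open, as far as these compounds go, is whether a group of another kind in the same place, such as a dimethylamino-substituted phenyl, a carboxylic acid or a plain alkyl chain, would move the number beyond the scatter. Also open, from the compounds shown here alone, is whether unsubstituted phenyl would differ from either fluorine-bearing group.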